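The source may report more compounds than this note shows. Statements on the series, on what has been measured and on what is new or still open speak of the compounds shown alone.

Measured compounds:
compound 1, `C=CCc1cc(C(=O)c2ccccc2)c(O)cc1OCCCCC#N`, 5%
compound 2, `C=CCc1cc(C(C)=O)c(O)cc1OCc1ccc(C#N)cc1`, 28%

In an assay on isolated protein for binding affinity to leukotriene B4 receptor 1 (Homo sapiens), tested at 1 uM (on this read-out higher numbers stand for more inhibition at the one concentration tested (going by the name of the read-out) and lower numbers for less inhibition), compound 2 gives 28%, the higher of the two numbers; compound 1 gives 5%, and the gap between compound 1 and compound 2 lies beyond the scatter. Going by the values given here, no step along a single change joins these two, so the comparison shows only what the two values show.

Compound 3, `CCc1cc(C(C)=O)c(O)cc1OCc1ccc(C#N)cc1`, is not yet measured. It differs from compound 2 in one place: methyl in place of vinyl on a saturated chain carbon bound to an aromatic carbon. The saturated chain bound to the aromatic carbon keeps its place and loses one carbon of length.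

Among the compounds with values here, no measured step of this kind is at hand, so the expectation rests on compound 2 alone. The step from compound 2 to compound 3 in this assay is expected to be small, a number 3 percentage points lower from compound 2 to compound 3 (within the scatter), and not beyond the scatter in either direction. Compound 3 is therefore estimated at 25% in this assay, with a range from 10% to 40%.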

Compound 3, a percentage reported as inhibition, at one concentration (the size of the read-out at that concentration, not a potency): 11%
Estimate against measurement, compound 3: 14 percentage points above, and the stated range covers the measured number.
By their numbers in this assay, from the lowest: compounds 1 and 3 (each within the scatter of the next); then compound 2.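

Going from allyl to ethyl on the shared core registers as a number 17 percentage points lower from compound 2 to compound 3 (beyond the scatter) in this assay and is the first change in one place among these compounds. Compound 1 and compound 2 differ in more than one place, so their values could not show that this read-out responds to the group on a saturated chain carbon bound to an aromatic carbon. The step is modest, yet it shows that this position is not indifferent to a change of only a vinyl for a methyl, which removes a double bond and shortens the chain together.

From the compounds shown here alone, whether the double bond or the chain length matters stays open, as a propyl chain would separate the two, and a longer chain or an amine at this place remains equally open. Nothing shown offers a measured reason for the step.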